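This account rests on a few compounds, and the source may have more. Where it says the series, first, only, none or still open, it means among the compounds named here.

Measured compounds:
compound 1, `CC(C)C(c1ccc(-c2ccc3cccc(F)c3c2)[nH]c1=O)C1NC(=O)NC1=O` — 320 nM
compound 2, `O=C1NC(=O)/C(=C/C(Cc2ccccc2)c2ccc(-c3ccc4cccc(F)c4c3)[nH]c2=O)O1` — 200 nM

Both compounds were tested in a functional assay on CHO cells for antagonist activity at prostaglandin E2 receptor EP3 subtype (Homo sapiens), read by cAMP accumulation, with a stated time of 30 min; on this read-out higher numbers stand for weaker inhibition and lower numbers for stronger inhibition. Compound 1 gives 320 nM and compound 2 gives 200 nM; the two values lie within the scatter of each other, so neither can be called the stronger antagonist on these numbers alone. Compound 1 is the compound whose value is the higher of the two, but only by a margin that repeated measurements would blur.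

Compound 3, `CC(C)C(/C=C1/C(=O)NC(=O)N1C)c1ccc(-c2ccc3cccc(F)c3c2)[nH]c1=O`, has not been measured. It differs from compound 1 in one place: a group of 9 heavy atoms (5 carbon, 2 nitrogen, 2 oxygen; one five-membered non-aromatic ring with 2 hetero atoms) in place of a group of 7 heavy atoms (3 carbon, 2 nitrogen, 2 oxygen; one five-membered non-aromatic ring with 2 hetero atoms), on a saturated chain carbon bound to an aromatic carbon and a saturated chain carbon. In words, a group of 9 heavy atoms (5 carbon, 2 nitrogen, 2 oxygen; one five-membered non-aromatic ring with 2 hetero atoms) takes the place of a group of 7 heavy atoms (3 carbon, 2 nitrogen, 2 oxygen; one five-membered non-aromatic ring with 2 hetero atoms), on a saturated chain carbon bound to an aromatic carbon and a saturated chain carbon.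

For the measured compounds named here, no measured pair shows this change directly. Compound 2, which also carries a ring joined through a double bond outside aromatic rings, sits within the scatter of compound 1, so no step beyond the scatter is expected in this assay in either direction. The expected step from compound 1 to compound 3 is a 1.3-fold lower number from compound 1 to compound 3 (0.11 log units; within the scatter). Compound 3 is therefore estimated at 250 nM, with a range from 80 nM to 800 nM.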

Compound 3, half-maximal inhibitory concentration: 11 nM
Estimate against measurement, compound 3: 23-fold (1.36 log units) above; the whole stated range lies above it.
By their numbers in this assay, from the lowest: compound 3; then compounds 2 and 1 (each within the scatter of the next).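

In this assay the saturated chain carbon bound to an aromatic carbon and a saturated chain carbon proves to be a place where the attached group matters a great deal: putting the group of 9 heavy atoms in place of the 2,5-dioxoimidazolidin-4-yl group gives a 29-fold lower number from compound 1 to compound 3 (1.46 log units; beyond the scatter) on the shared core. Both groups hold one five-membered non-aromatic ring with 2 hetero atoms and 2 hydrogen-bond acceptors, and neither carries a net charge, so a large step appears here even though those counts stay the same. What does differ is the number of heavy atoms, 9 against 7, of double bonds outside aromatic rings, 3 against 2, and of hydrogen-bond donors, 1 against 2, and no measurement given here explains the size of the step.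

These differences arrive together in a single change, so the compounds shown leave open which of them accounts for the step. They also leave open how this place responds to quite different groups, such as a carboxylic acid, an amine or a longer chain.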